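The compounds below may be only part of what the source reports. "The series", "measured", "known", "first", "only" and "open" are said of these compounds alone.

Compound 1 `O=C(Nc1cccc(-c2oc3cc(-c4ccc(F)cc4)ccc3c(=O)c2O)c1)c1ccccc1F`: 10800 nM
Compound 2 `O=C(Nc1cccc(-c2oc3cc(-c4ccc(F)cc4)ccc3c(=O)c2O)c1)c1ccc(F)cc1`: 14200 nM

Compound 2 holds the highest of the two numbers in a functional assay on HCC1937 cells (Homo sapiens) for antiproliferative activity, read by CCK-8 assay, with a stated time of 72 h (on this read-out higher numbers stand for weaker inhibition and lower numbers for stronger inhibition), with compound 1 nearest at a 1.3-fold higher number from compound 1 to compound 2 (0.12 log units; within the scatter). Compound 3 `COc1ccc(C(=O)Nc2cccc(-c3oc4cc(-c5ccc(F)cc5)ccc4c(=O)c3O)c2)cc1` carries methoxy in place of fluoro on an aromatic carbon. Going by the values given here, the only measured step, from the 2-fluorophenyl to the 4-fluorophenyl on the carbonyl carbon, stayed within the scatter, and no measured pair speaks directly to methoxy in place of fluoro, so no shift beyond the scatter is expected for compound 3, with a 1.2-fold lower number from compound 2 to compound 3 (0.07 log units; within the scatter) as the estimated step. Compound 3 is estimated at 12000 nM, within 5000 nM to 30000 nM.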

Compound 3, half-maximal inhibitory concentration: 5490 nM
Compound 3: middle estimate off by 2.2-fold (0.34 log units), on the high side; the range from low to high includes it.
By their numbers in this assay, from the lowest: compounds 3, 1 and 2 (each within the scatter of the next, the first and the last beyond it).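

Methoxy in place of fluoro on this aromatic carbon, para to a large group, gives the first step beyond the scatter in this assay (a 2.6-fold lower number from compound 2 to compound 3 (0.41 log units; beyond the scatter)), though a modest one. Against the 2-fluorophenyl, the 4-methoxyphenyl stays within the scatter (a 2.0-fold lower number from compound 1 to compound 3 (0.29 log units; within the scatter)), so compound 3 separates clearly from compound 2 only. Nothing available explains this step.

From the compounds shown here alone, whether an amine or a carboxylic acid in place of the methoxy would take the number further remains open, as does whether a longer alkoxy chain would keep this step.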